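Taking the silicon-bearing group off compound 1

The source may report more compounds than this note shows. Statements on the series, on what has been measured and on what is new or still open speak of the compounds shown alone.

Values in an ADME assay on HEp-2 cells (Homo sapiens) for cytotoxicity, read by MTT assay, with a stated time of 72 h; a higher number here means a weaker inhibitor, a lower number a stronger inhibitor
- compound 1 `COc1ccc(OC)c(C2=C(c3cc(OC)c(OC)c(OC)c3)C(=O)CC2O[SiH2]C(C)(C)C)c1` gives 19 ug/mL
- compound 2 `COc1cc(C2=C(c3ccccc3)C(O[SiH2]C(C)(C)C)CC2=O)cc(OC)c1OC` gives > 100 ug/mL (a limit of the assay)

Within the data shown here, compound 1 holds the only true number so far, and the entry for compound 2 is only a limit. Compound 3 `COc1ccc(OC)c(C2=C(c3cc(OC)c(OC)c(OC)c3)C(=O)CC2O)c1` keeps the core of compound 1 and differs by one change: a hydrogen atom in place of a group of 5 heavy atoms (4 carbon, 1 silicon; no ring), on an oxygen on a saturated carbon. Among the measured compounds shown here, the one measured step is an at least 5.2-fold higher number from compound 1 to compound 2 (0.72 log units; beyond the scatter). That step replaces 2,5-dimethoxyphenyl with phenyl on a double-bonded ring carbon, a different part of the molecule, so it sets no size for this change. It shows only that this assay can respond to a structural change. The expected change is a 1.3-fold lower number from compound 1 to compound 3 (0.10 log units; within the scatter), so no step beyond the scatter is expected, though with wide uncertainty. For compound 3 the estimate is 15 ug/mL, with an expected range from 3 ug/mL to 80 ug/mL.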

Compound 3, half-maximal inhibitory concentration: > 100 ug/mL
Compound 3 ended at the assay's limit (the forecaster's own chance of this, stated with the estimate: 15%); middle value at least 6.6-fold (0.82 log units) away from the limit.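

In this assay, the group on this oxygen turns out to matter: leaving a hydrogen atom in its place gives an at least 5.2-fold higher number from compound 1 to compound 3 (0.72 log units; beyond the scatter). Compound 3 gives > 100 ug/mL, which is a limit of the assay and not a number. So a measurable value in compound 1 depends on the silicon-bearing group as well as on the 2,5-dimethoxyphenyl group changed in compound 2, but the true size of this step stays unknown, since the readings stop at the same limit: the limit of > 100 ug/mL in this assay, at which 2 of the 3 values shown sit.

The compounds shown leave open whether this particular silicon-bearing group is needed, or whether another group on the same oxygen, such as a methyl group, an acetyl group or a longer carbon chain, would also keep a measurable value. They also do not tell how far beyond the limit compound 3 really lies.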